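A few compounds are considered here, and "the series" means these few. Any claim that something is new, unique, unknown or untested is made for them only; others in the source may bear on it.

Measured so far:
Compound 1 `O=C(Nc1ccc(Oc2ccnc3[nH]ccc23)cc1)c1cn(-c2ccccc2)c2ccccc2c1=O`: 3560 nM
Compound 2 `Cn1ccc2c(Oc3ccc(NC(=O)c4cn(-c5ccccc5)c5ccccc5c4=O)cc3F)ccnc21`: 2790 nM

In a functional assay on MCF7 cells (Homo sapiens) for inhibition, read by MTT assay, with a stated time of 72 h (a lower number here means a stronger inhibitor, a higher number a weaker inhibitor), compound 2 gives the lowest of the two numbers, and the number for compound 1 sits within the usual scatter of it, so no order between the two can be claimed. Compound 3 `O=C(Nc1ccc(Oc2ccnc3[nH]ccc23)c(F)c1)c1cn(-c2ccccc2)c2ccccc2c1=O` differs from compound 2 by hydrogen in place of methyl on an aromatic nitrogen, a hydrogen in place of methyl on an aromatic nitrogen. Among the measured compounds shown here, no measured pair shows this change alone, so its size is unknown here. The expected step from compound 2 is small, a 1.1-fold higher number from compound 2 to compound 3 (0.03 log units; within the scatter), with no direction beyond the scatter. Compound 3 is therefore estimated at 3000 nM, within 1400 nM to 6500 nM.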

Compound 3, half-maximal inhibitory concentration: 430 nM
Estimate against measurement, compound 3: 7.0-fold (0.84 log units) above, outside the stated range (below it).
By their numbers in this assay, from the lowest: compound 3; then compounds 2 and 1 (each within the scatter of the next).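

In this assay, hydrogen in place of methyl on an aromatic nitrogen gives a 6.5-fold lower number from compound 2 to compound 3 (0.81 log units; beyond the scatter) and so is far from the small step one might assume: with fluoro present, this nitrogen is a sensitive place. Fluoro in place of hydrogen on an aromatic carbon gives an 8.3-fold lower number from compound 1 to compound 3 (0.92 log units; beyond the scatter) when that nitrogen carries hydrogen, so this second place also counts. No supporting measurement explains either step.

Going by these compounds, whether an ethyl group or a longer chain on that nitrogen would behave like methyl remains open. So does whether chloro could stand in for the fluoro.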